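This account rests on a few compounds, and the source may have more. Where it says the series, first, only, none or still open, it means among the compounds named here.

Measured so far in a functional assay on the whole organism (stomach) with Rattus norvegicus as the target; on this read-out lower numbers stand for an effect already at smaller amounts and higher numbers for an effect only at larger amounts of compound:

compound 1 `C/N=C(/NC#N)NCCCCCCn1nc(-c2ccccc2)ccc1=O` gives > 100 mg/kg
compound 2 `C/N=C(/NC#N)NCCCCCn1nc(-c2ccccc2)ccc1=O` gives 100 mg/kg
compound 3 `C/N=C(/NC#N)NCCCCn1nc(-c2ccccc2)cc(C)c1=O` gives 60.8 mg/kg

The value of compound 1 is a limit of the assay, not a measured number (the limit of > 100 mg/kg in this assay, at which 1 of the 3 values shown sits). Compound 2 and compound 3 give numbers that lie within the scatter of each other, so no order between them is claimed. Between compound 1 and compound 2 the structural change is a group of 7 heavy atoms (3 carbon, 4 nitrogen; no ring) in place of a group of 8 heavy atoms (4 carbon, 4 nitrogen; no ring), on a saturated chain carbon, five bonds along the chain from an aromatic nitrogen, and the step measured with it is a number no higher from compound 1 to compound 2 (the limit leaves the size open).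

Compound 4 `C/N=C(/NC#N)NCCCn1nc(-c2ccccc2)cc(C)c1=O` has not yet been measured in this assay. It differs from compound 3 by a group of 7 heavy atoms (3 carbon, 4 nitrogen; no ring) in place of a group of 8 heavy atoms (4 carbon, 4 nitrogen; no ring), on a saturated chain carbon, three bonds along the chain from an aromatic nitrogen. Within the data shown here, this is the same kind of change as the one from compound 1 to compound 2, not the same: there the place is five bonds along the chain from an aromatic nitrogen, here three bonds. The difference between the core of compound 1 and the core of compound 3 is not broken down here.

Because the step of a number no higher from compound 1 to compound 2 (the limit leaves the size open) leaves its size open, the expectation for compound 4 rests mainly on compound 3 and its value 60.8 mg/kg, with a step of similar kind assumed to be small. The expected step is a 1.2-fold lower number from compound 3 to compound 4 (0.08 log units; within the scatter). For compound 4 the estimated value is 50 mg/kg, expected to fall between 20 mg/kg and 150 mg/kg.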

Compound 4, dose for half-maximal effect: > 100 mg/kg
Compound 4: only a limit was reported; the forecaster's own chance of this, stated with the estimate: 15%; at least 2.0-fold (0.30 log units) between middle value and limit.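

In this assay compound 4 gives only a limit of the assay, > 100 mg/kg. The group of 7 heavy atoms in place of the group of 8 heavy atoms, on a saturated chain carbon, three bonds along the chain from an aromatic nitrogen, goes with an at least 1.6-fold higher number from compound 3 to compound 4 (0.21 log units; that floor lies within the scatter), and this is a floor rather than a measured size. The change therefore points the same way on neither core with any certainty, and the data do not show whether its effect carries over from one core to the other, because limits stand in both steps: the same change on two cores in this assay, a number no higher (the limit leaves the size open) from compound 1 to compound 2 and an at least 1.6-fold higher number (0.21 log units; that floor lies within the scatter) from compound 3 to compound 4; the limit leaves it open whether they differ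

On these data alone, it remains open how the core of compound 3 would read in this assay with a longer chain, or with an amine at the chain end in place of the present group. How much of these numbers belongs to the core itself also stays unresolved.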